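A few compounds are considered here, and "the series" means these few. Any claim that something is new, unique, unknown or untested is made for them only; others in the source may bear on it.

Measured compounds:
compound 1, `Cc1ccc(C(=O)Nc2cccc(-c3ccnc4c(N)cccc34)c2)cc1C`, in a functional assay on A375P cells (Homo sapiens) for antiproliferative activity, read by MTT assay, with a stated time of 48 h (a lower number here means a stronger inhibitor, a higher number a weaker inhibitor), compound 1 gives > 20000 nM, which is a limit of the assay and not a number.
compound 2, `CC(=O)Nc1cccc2c(-c3cccc(NC(=O)c4ccc(C)c(C)c4)c3)ccnc12`, in this assay compound 2 gives > 20000 nM, likewise a limit and not a number.

Compound 2 therefore stands at the limit, where (the limit of > 20000 nM in this assay, at which 2 of the 2 values shown sit). Going by the values given here, the one step among the measured compounds, a step that the two limits leave unreadable from compound 1 to compound 2, is the replacement of hydrogen by acetyl on a nitrogen on an aromatic ring, and its size cannot be read.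

Compound 3, `CC(=O)Nc1cccc2c(-c3cccc(NC(=O)c4ccc(C(F)(F)F)c(Cl)c4)c3)ccnc12`, differs from compound 2 by 3-chloro-4-(trifluoromethyl)phenyl in place of 3,4-dimethylphenyl on a carbonyl carbon. Among the compounds with values here, no measured step touches this part of the structure, and the one step that exists is itself unreadable, so no size or direction for the change in this assay can be drawn from the numbers. The estimate for compound 3 is thus broad: compound 3 is expected to give 5000 nM, between 500 nM and 30000 nM, a step of an at least 4.0-fold lower number from compound 2 to compound 3 (0.60 log units; beyond the scatter) that is an estimate rather than a reading.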

Compound 3, half-maximal inhibitory concentration: 7600 nM
The estimate for compound 3 lay 1.5-fold (0.18 log units) below the measured number; low and high end bracket the measured number.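

In this assay, going by these compounds alone, 3-chloro-4-(trifluoromethyl)phenyl in place of 3,4-dimethylphenyl on the carbonyl carbon gives an at least 2.6-fold lower number from compound 2 to compound 3 (0.42 log units; beyond the scatter), the first step that can be read. It shows that the group on this carbonyl carbon can move the read-out from the assay limit to a measured number, at least with the acetyl on the aromatic nitrogen in place. The full size of the step remains unknown, because compound 2 gives a limit and not a number: the limit of > 20000 nM in this assay, at which 2 of the 3 values shown sit.

Chlorine and trifluoromethyl enter together, so the compounds shown do not tell which of them carries the step, or how a phenyl bearing a methoxy group or a nitrile would read. Going by these compounds, the step from compound 1 to compound 2 cannot be read, so the effect of the acetyl on that nitrogen also remains open.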